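The source may report more compounds than this note shows. Statements on the series, on what has been measured and on what is new or still open speak of the compounds shown alone.

Compound 3 `Cc1nnc(CN2CCCC2)n1-c1ccc(Cl)cc1C(=O)c1ccccc1` stands at 1.3 mg/kg in a functional assay on the whole organism (strain CF-1) with Mus musculus as the target; on this read-out lower numbers stand for an effect already at smaller amounts and higher numbers for an effect only at larger amounts of compound. Compound 2 `Cc1nnc(CN(C)C)n1-c1ccc(Cl)cc1C(=O)c1ccccc1` sits close to it at 2.2 mg/kg, since a 1.7-fold lower number from compound 2 to compound 3 (0.23 log units; within the scatter). Compound 1 `Cc1nnc(CN2CCCC2)n1-c1ccc(Cl)cc1Cc1ccccc1` lies far higher at 40 mg/kg, and a 31-fold lower number from compound 1 to compound 3 (1.49 log units; beyond the scatter). Compound 4 `Cc1nnc(CN2CCCC2)n1-c1ccc(Cl)cc1C(=O)c1ccccc1Cl` differs from compound 3 by chloro in place of hydrogen on an aromatic carbon. Neither measured step touches this part of the molecule: the change from compound 1 to compound 3 swaps benzyl for benzoyl, and the change from compound 2 to compound 3 swaps dimethylamino for pyrrolidin-1-yl. Among the compounds with values here, no measured step therefore points to a direction, and in this assay a step within the scatter is expected, so that no change at the digits printed from compound 3 to compound 4 (within the scatter) is the estimate. For compound 4 the expected value is 1.3 mg/kg, with a range from 0.5 mg/kg to 4 mg/kg.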

Compound 4, dose for half-maximal effect: 1 mg/kg
Beside the measured number, compound 4's estimate is 1.3-fold (0.11 log units) above it; the range from low to high includes it.
By their numbers in this assay, from the lowest: compounds 4, 3 and 2 (each within the scatter of the next, the first and the last beyond it); then compound 1.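

Chloro can sit on this aromatic carbon, ortho to a large group, without a change that stands out from the scatter in this assay, with a 1.3-fold lower number from compound 3 to compound 4 (0.11 log units; within the scatter). The large difference between the benzyl and benzoyl compounds also remains when the benzoyl carries this chloro, with a 40-fold lower number from compound 1 to compound 4 (1.60 log units; beyond the scatter). Nothing available here explains why the chloro leaves the dose so little changed. The compounds shown leave open how fluoro, methoxy or a carboxylic acid would read at this position. They also leave open whether chloro elsewhere on this ring would give a similar number.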